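Swapping a Trifluoromethylphenyl for a Hydroxyphenyl

This account rests on a few compounds, and the source may have more. Where it says the series, first, only, none or still open, it means among the compounds named here.

Measured so far:
- compound 1, `Cn1c(=O)c(=O)n(C2CCCC2)c2nc(N/N=C/c3ccc(C(F)(F)F)cc3)ncc21`: 23600 nM
- compound 2, `Cn1c(=O)c(=O)n(C2CCCC2)c2nc(N/N=C/c3cc(C(F)(F)F)cc(C(F)(F)F)c3)ncc21`: 8200 nM

Both compounds share one core and differ only in the aromatic group hanging from the carbon with a double bond to nitrogen. In a functional assay on PC-3 cells (Homo sapiens) for antiproliferative activity, read by MTT assay (a lower number here means a stronger inhibitor, a higher number a weaker inhibitor), compound 1 gives 23600 nM, the higher of the two numbers measured, so it is the weaker of the pair; compound 2 sits at 8200 nM, and that gap lies beyond the usual scatter.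

Compound 3, `Cn1c(=O)c(=O)n(C2CCCC2)c2nc(N/N=C/c3cccc(O)c3)ncc21`, has not yet been measured. It differs from compound 1 in one place: 3-hydroxyphenyl in place of 4-(trifluoromethyl)phenyl on a carbon with a double bond to nitrogen

Among the compounds with values here, no measured pair shows what this particular swap does, so the expectation rests on the shared core alone and is loose. The step is expected to be a 1.3-fold higher number from compound 1 to compound 3 (0.10 log units; within the scatter), which is small enough to fall within the scatter in either direction. Compound 3 is therefore estimated at 30000 nM, with a range from 8000 nM to 100000 nM.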

Compound 3, half-maximal inhibitory concentration: 36300 nM
The estimate for compound 3 lay 1.2-fold (0.08 log units) below the measured number, and the stated range covers the measured number.
By their numbers in this assay, from the lowest: compound 2; then compounds 1 and 3 (each within the scatter of the next).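

In this assay the exchange of 4-(trifluoromethyl)phenyl for 3-hydroxyphenyl gives a 1.5-fold higher number from compound 1 to compound 3 (0.19 log units; within the scatter) and so cannot be told apart from the ordinary spread of repeated measurements. At this position, on a carbon with a double bond to nitrogen, a group with no hydrogen-bond donor and a group with one therefore give readings that do not separate, even though the entering group also has fewer heavy atoms. Nothing available here explains this result.

The exchange alters several features at once, so the effect of the hydroxyl alone remains unresolved. Going by these compounds, it also remains open whether a phenyl ring carrying an amine or a carboxylic acid, or a longer chain in place of the ring, would move the number beyond the scatter.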